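The source may report more compounds than this note shows. Statements on the series, on what has been measured and on what is new or still open speak of the compounds shown alone.

Two amides that share one core have been read so far in a physicochemical assay for lipophilicity, read by HPLC, at pH 2; a higher number here means a more lipophilic compound, a lower number a more polar compound. Compound 1 (`O=C(O)c1cnn(-c2cccc(-c3cccc(C(=O)N4CCCCC4)c3F)c2)c1C1CC1`) gives 2.3, and compound 2 (`CN(CC1CC1)C(=O)c1cccc(-c2cccc(-n3ncc(C(=O)O)c3C3CC3)c2)c1F`) gives 2.2. These two numbers lie within the scatter of each other, so compound 2 cannot be placed apart from compound 1. Compound 3 (`CN(C)C(=O)c1cccc(-c2cccc(-n3ncc(C(=O)O)c3C3CC3)c2)c1F`) is the next to be read. Here hydrogen takes the place of cyclopropyl on a saturated chain carbon bound to an amide-type nitrogen, which turns cyclopropylmethyl into methyl: hydrogen in place of cyclopropyl on a saturated chain carbon bound to an amide-type nitrogen.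

Among the compounds with values here, only one measured step bears on this, and only loosely. In a number 0.10 log units lower from compound 1 to compound 2 (within the scatter), (cyclopropylmethyl)(methyl)amino replaces piperidin-1-yl on a carbonyl carbon. That is an exchange of one amide group for another, whereas in compound 3 carbon leaves and only hydrogen enters. The measured step therefore sets no size for this change, and the expectation rests on the structural change itself. The expected step is a number 0.60 log units lower from compound 2 to compound 3 (beyond the scatter), downward and beyond the scatter. Compound 3 is estimated at 1.6, with an expected range from 1.3 to 1.9.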

Compound 3, distribution coefficient: 1.3
For compound 3 the middle estimate is 0.30 log units above the measured one, and the stated range covers the measured number.
By their numbers in this assay, from the lowest: compound 3; then compounds 2 and 1 (each within the scatter of the next).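

In this assay, within the data shown here, the amide end of the shared core responds clearly for the first time: with hydrogen in place of cyclopropyl on a saturated chain carbon bound to an amide-type nitrogen, the result is a number 0.90 log units lower from compound 2 to compound 3 (beyond the scatter), whereas the earlier exchange of one amide group for another gave only a number 0.10 log units lower from compound 1 to compound 2 (within the scatter). Dimethylamino in place of piperidin-1-yl on a carbonyl carbon gives a number 1.00 log units lower from compound 1 to compound 3 (beyond the scatter), so the ring-containing piperidin-1-yl and (cyclopropylmethyl)(methyl)amino cannot be told apart here, while dimethylamino stands apart from both. The shift is clear in size, but no separate measurement explains why it occurs.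

The compounds shown cannot say whether the drop follows the three-membered ring specifically or simply the loss of its three carbons, a question that a propyl chain at the same place could help to settle. As far as these compounds go, it is also open how this reading would respond if a hydroxyl group or an amine were carried on that chain, rather than only carbon and hydrogen.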